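Ethyl in place of but-1-yn-1-yl on a nucleoside core

The source may hold more compounds than are shown below. What is called first, only, known or untested is meant among the compounds shown, and "the series" means these compounds.

Measured compounds:
- compound 1, `CCC#C[C@@]1(O)[C@@H](CO)O[C@@H](n2ccc(N)nc2=O)[C@@H]1O`: 108000 nM
- compound 2, `C#C[C@@H]1[C@@H](O)[C@H](n2ccc(=O)[nH]c2=O)O[C@@H]1CO`: > 350000 nM
- compound 3, `C#CC[C@]1(O)[C@@H](CO)O[C@@H](n2ccc(=O)[nH]c2=O)[C@@H]1O`: > 350000 nM

Three compounds were tested in a functional assay on KB cells (Homo sapiens), read by MTT assay; a lower number here means a stronger inhibitor, a higher number a weaker inhibitor. Among the measured compounds shown here, compound 1 gives 108000 nM and is the only one with a measured number. For compound 2 the assay reports only a limit, > 350000 nM. For compound 3 it likewise reports only a limit, > 350000 nM. For the measured compounds named here, the two limits sit together, (the limit of > 350000 nM in this assay, at which 2 of the 3 values shown sit), so compound 1 stands alone as the one compound with a value inside the measurable range, and even that value is high.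

Compound 4, `CC[C@@]1(O)[C@@H](CO)O[C@@H](n2ccc(N)nc2=O)[C@@H]1O`, is not yet measured. It differs from compound 1 in one place: ethyl in place of but-1-yn-1-yl on a saturated ring carbon. Going by the values given here, since no measured pair differs by only one change, there is no directly comparable step to lean on. Given that compound 1 already sits near the upper edge of the measurable range, the expected step of a 1.9-fold higher number from compound 1 to compound 4 (0.27 log units; within the scatter) is a move toward weaker inhibition, small in size and possibly beyond what the assay can resolve. Compound 4 is estimated at 200000 nM, with a range from 60000 nM to 350000 nM.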

Compound 4, half-maximal inhibitory concentration: 258000 nM
For compound 4 the middle estimate is 1.3-fold (0.11 log units) below the measured one, within the range that was stated.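

In this assay, among the compounds shown here, putting ethyl in place of but-1-yn-1-yl on this saturated ring carbon gives a 2.4-fold higher number from compound 1 to compound 4 (0.38 log units; beyond the scatter), the first comparison here in which only one place changes. The group at this position therefore does affect the reading, but only modestly, and inhibition remains weak with either group. Compound 4 still gives a measured number rather than a limit, so this step can be read in full, although the value lies not far from the ceiling of the assay: the limit of > 350000 nM in this assay, at which 2 of the 4 values shown sit.

The change shortens the chain and removes the triple bond together, so the compounds shown leave open which of the two accounts for the step. A butyl chain at this carbon would separate the two, while an amine there would test whether a quite different kind of group is tolerated.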